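The source may hold more compounds than are shown below. What is called first, only, known or untested is meant among the compounds shown, and "the series" means these compounds.

Working notes on the series. Compound 1 `COc1ccc2[nH]cc(C3(c4c[nH]c5ccc(OC)cc45)C(=O)Nc4ccccc43)c2c1` is tested in a functional assay on A549 cells (Homo sapiens) for cytotoxicity, read by MTT assay, with a stated time of 48 h (a higher number here means a weaker inhibitor, a lower number a stronger inhibitor), and gives 11200 nM. Compound 2 `COc1ccc2c(C3(c4c[nH]c5cc(OC)ccc45)C(=O)Nc4ccccc43)c[nH]c2c1` carries the same substituents with the methoxy groups placed differently on the two indole rings, and in this assay compound 2 gives 7800 nM. Going by the values given here, of the two numbers known so far, compound 1 has the higher one, but its gap to compound 2 lies within the usual scatter of such measurements, so the two cannot be ranked against each other.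

Compound 3 `COc1ccc2[nH]cc(C3(c4c[nH]c5ccc(OC)cc45)C(=O)Nc4ccc(F)cc43)c2c1` is the next member and has not yet been measured in this assay. It differs from compound 1 by fluoro in place of hydrogen on an aromatic carbon. Among the compounds with values here, no step between measured compounds shows the effect of such a change, so the expectation rests only on the value of compound 1, 11200 nM, and on the change being a single small substituent at the edge of the shared core. The step of a 1.2-fold lower number from compound 1 to compound 3 (0.09 log units; within the scatter) is expected to be small, in either direction, and not clearly beyond the scatter. Compound 3 is estimated at 9000 nM in this assay, with a range from 4000 nM to 22000 nM.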

Compound 3, half-maximal inhibitory concentration: 10600 nM
Estimate against measurement, compound 3: 1.2-fold (0.07 log units) below; the measured number falls inside the stated range.
By their numbers in this assay, from the lowest: compounds 2, 3 and 1 (each within the scatter of the next).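

In this assay, the step for fluoro in place of hydrogen on an aromatic carbon, meta to a fused ring and para to a fused ring, is a 1.1-fold lower number from compound 1 to compound 3 (0.02 log units; within the scatter) and gives the series its first readable single-place change. At this position on the shared core, a single fluoro atom therefore gives a number that cannot be told apart from that of the parent with hydrogen, although this is one substituent at one position in one assay. Nothing measured here offers an explanation for this outcome.

As far as these compounds go, whether an amine, a carboxylic acid or a longer alkyl chain at this position would give a step beyond the scatter remains open. Also open, from the compounds shown here alone, is whether fluoro would behave in the same way on compound 2, with its differently placed methoxy groups.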